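This account rests on a few compounds, and the source may have more. Where it says the series, first, only, none or still open, it means among the compounds named here.

Measured so far:
- compound 1, `NS(=O)(=O)NC[C@H]1CC[C@H](C(=O)/C(=N/O)Nc2ccc(F)c(Br)c2)CC1`: 58700 nM
- compound 2, `O=C(/C(=N/O)Nc1ccc(F)c(Br)c1)C1CCN(C(=O)NCc2ccccc2)CC1`: 89800 nM

In an assay for inhibition of Tryptophan 2,3-dioxygenase (Homo sapiens), with a stated time of 1 h (on this read-out higher numbers stand for weaker inhibition and lower numbers for stronger inhibition), compound 1 gives 58700 nM, and compound 2 gives 89800 nM; these two numbers lie within the scatter of each other, so neither stands apart. Compound 3, `O=C(/C(=N/O)Nc1ccc(F)c(Br)c1)C1CCN(c2ccccc2)CC1`, has not been measured. It differs from compound 2 as follows: phenyl in place of benzylcarbamoyl on an amine nitrogen in a ring. Within the data shown here, no step between measured compounds resembles this change, so no direction is known from the data. With so little to go on, compound 3 is expected to show a 1.3-fold lower number from compound 2 to compound 3 (0.11 log units; within the scatter), a step not beyond the scatter. The estimate for compound 3 in this assay is 70000 nM, between 20000 nM and 250000 nM.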

Compound 3, half-maximal inhibitory concentration: > 100000 nM
Compound 3 gave a limit, no number (the forecaster's own chance of this, stated with the estimate: 25%); middle value at least 1.4-fold (0.15 log units) from the limit.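

In this assay compound 3 gives > 100000 nM, which is a limit of the assay and not a number. Phenyl in place of benzylcarbamoyl on an amine nitrogen in a ring gives an at least 1.1-fold higher number from compound 2 to compound 3 (0.04 log units; that floor lies within the scatter), so this change shows no sign of stronger inhibition, although the true size of the step stays unknown. Compound 3 therefore offers a limit rather than a ranking: the limit of > 100000 nM in this assay, at which 1 of the 3 values shown sits.

The compounds shown leave open what a methyl, an acetyl or a longer chain ending in a carboxylic acid would do on this nitrogen.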